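The compounds below may be only part of what the source reports. "The series", "measured", "known", "first", "only" and "open" are said of these compounds alone.

In an assay on cells for binding affinity to Neuropeptide Y receptor type 1 (Homo sapiens) (a lower number here means a stronger inhibitor, a higher number a weaker inhibitor), compound 2 `CC/C=C\CCOc1cc(CCc2nc(C)c(CC)s2)nc(NCc2cc(Cl)cc(NC(=O)OC(C)C)c2)c1` gives 4.7 nM, the lowest of the three numbers in hand. Compound 1 `CCCCOc1cc(CCc2nc(C)c(CC)s2)nc(NCc2cc(Cl)cc(NC(=O)OC(C)C)c2)c1` gives 16 nM, and compound 3 `CCc1sc(CCc2cc(OC3CCCCC3)cc(NCc3cc(Cl)cc(NC(=O)OC(C)C)c3)n2)nc1C` gives 29 nM. Among these three, a 3.4-fold lower number from compound 1 to compound 2 (0.53 log units; beyond the scatter), while a 1.8-fold higher number from compound 1 to compound 3 (0.26 log units; within the scatter), and a 6.2-fold higher number from compound 2 to compound 3 (0.79 log units; beyond the scatter).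

Compound 4 `CCc1sc(CCc2cc(OC3CCOCC3)cc(NCc3cc(Cl)cc(NC(=O)OC(C)C)c3)n2)nc1C` has not yet been measured in this assay. It differs from compound 2 in one place: oxan-4-yl in place of hex-3-en-1-yl on an oxygen on an aromatic ring. Two of the measured steps bear on this change. The step from compound 2 to compound 3 also exchanges the hex-3-en-1-yl chain on the same oxygen for a six-membered ring, and it was a modest rise beyond the scatter. The step from compound 1 to compound 3 exchanges a saturated chain for the same ring and stayed within the scatter. Nothing measured here speaks to a ring that carries an oxygen and a hydrogen-bond acceptor.

Within the data shown here, on this basis compound 4 is expected to give a modestly higher number than compound 2 in this assay, because a 6.2-fold higher number from compound 2 to compound 3 (0.79 log units; beyond the scatter) is the closest precedent. The estimate for compound 4 is 40 nM, within a range from 15 nM to 120 nM, which would mean an 8.5-fold higher number from compound 2 to compound 4 (0.93 log units; beyond the scatter).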

Compound 4, half-maximal inhibitory concentration: 4.4 nM
Beside the measured number, compound 4's estimate is 9.1-fold (0.96 log units) above it, and the stated range ends above it.
By their numbers in this assay, from the lowest: compounds 4 and 2 (each within the scatter of the next); then compounds 1 and 3 (each within the scatter of the next).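

Until now, the only ring on this oxygen was cyclohexyl, and it gave the highest number of the series. In this assay, oxan-4-yl in place of cyclohexyl gives a 6.6-fold lower number from compound 3 to compound 4 (0.82 log units; beyond the scatter), so replacing one ring carbon with oxygen separates these two six-membered rings by more than the scatter. A ring on this oxygen is therefore compatible with a number matching that of the hex-3-en-1-yl chain, with a 1.1-fold lower number from compound 2 to compound 4 (0.03 log units; within the scatter), and oxan-4-yl also compares well with the butyl chain, with a 3.6-fold lower number from compound 1 to compound 4 (0.56 log units; beyond the scatter). Nothing available here explains why the ring oxygen has this effect.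

From the compounds shown here alone, it remains open whether the oxygen needs to sit within a ring, which an open chain such as 2-methoxyethyl on the same oxygen would test. Going by these compounds, it is equally open whether another ring would behave like oxan-4-yl, for instance the smaller oxetan-3-yl or piperidin-4-yl, which carries an amine in place of the ring oxygen.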